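From Methyl to Isopropyl on an Inactive Compound

The source may report more compounds than this note shows. Statements on the series, on what has been measured and on what is new or still open speak of the compounds shown alone.

In a functional assay on HeLa cells (Homo sapiens) for cytotoxicity, read by MTT assay (a lower number here means a stronger inhibitor, a higher number a weaker inhibitor), compound 1 `COC(=O)C[C@@H]1C[C@@H](O)[C@H](C)[C@H](c2ccccc2)N1` gives 6500 nM. Compound 2 `COC(=O)C[C@H]1C[C@H](O)[C@@H](C)[C@@H](c2ccc(C)cc2)N1` is reported as "not active" (no number reported), so it stands without a single number and offers no exact point from which to measure a change. Within the data shown here, no pair of tested compounds here differs in just one place, which means the data do not directly show how a change on the aromatic ring moves the result.

The next structure is compound 3 `COC(=O)C[C@H]1C[C@H](O)[C@@H](C)[C@@H](c2ccc(C(C)C)cc2)N1`. Among the measured compounds shown here, its one change is isopropyl in place of methyl on an aromatic carbon, para to a large group.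

With no number for the starting point, the size of this step cannot be stated exactly. The expectation is a modest shift at most, with no clear gain in strength beyond the usual scatter of repeated measurements. For the measured compounds named here, the only number to lean on is the 6500 nM of compound 1, so a weak result seems likely, and a report with no number is quite possible. For compound 3, the estimated half-maximal inhibitory concentration is 15000 nM, with an expected range of 5000 nM to 50000 nM.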

Compound 3, half-maximal inhibitory concentration: 18200 nM
For compound 3 the middle estimate is 1.2-fold (0.08 log units) below the measured one, within the range that was stated.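

No step can be read from compound 2 to compound 3: compound 2 is reported as not active with no number, so compound 3 at 18200 nM has nothing exact to be compared with. The compounds shown leave open how changing methyl to isopropyl on the aromatic ring alters the result in this assay on its own. No supporting measurement is available to explain this result.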